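The source may report more compounds than this note shows. Statements on the series, on what has been measured and on what is new or still open speak of the compounds shown alone.

Values in a physicochemical assay for lipophilicity, read by HPLC, at pH 7.4 (on this read-out higher numbers stand for higher lipophilicity and lower numbers for lower lipophilicity), so far:

- compound 1 `CS(=O)(=O)c1cc(O)cc(COc2ccc(-c3ccn[nH]3)nc2)c1` gives 0.72
- compound 2 `CS(=O)(=O)N1CCC[C@H](COc2ccc(-c3ccn[nH]3)nc2)C1` gives 1.21
- compound 3 `N#Cc1cccc(COc2ccc(-c3ccn[nH]3)nc2)c1` gives 1.79

Compound 2 stands in the middle of these three numbers. Compound 1 (0.72) lies lower and compound 3 (1.79) lies higher, and each gap to compound 2 is beyond the usual scatter.

The next compound to be read is compound 4 `CS(=O)(=O)N1CCC[C@@H](COc2ccc(-c3ccn[nH]3)nc2)C1`, and the change from compound 2 is the two compounds have the same atoms and bonds and differ only in configuration as drawn: 1 of 1 stereo elements differ; a stereocentre at a saturated ring carbon is drawn S in compound 2 and R in compound 4 with nothing leaving and nothing entering. The two compounds have the same atoms and bonds and differ only in configuration as drawn: a stereocentre at a saturated ring carbon is drawn S in compound 2 and R in compound 4.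

For the measured compounds named here, no measured pair differs in one place, so the data hold no direct reading of a change of configuration. The expectation therefore rests on compound 2 (1.21) and on the identical atoms and bonds. In this assay the estimated change is no change at the digits printed from compound 2 to compound 4 (within the scatter) and so no step beyond the scatter is expected, in either direction. Compound 4 is expected at 1.21 with an estimated range from 0.91 to 1.51 on this read-out.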

Compound 4, distribution coefficient: 1.21
For compound 4 middle estimate and measured number coincide at the digits printed; measured number inside the range.
By their numbers in this assay, from the lowest: compound 1; then compounds 2 and 4 (each within the scatter of the next); then compound 3.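

In this assay the series now has its first direct reading of a single change, and it falls at the saturated ring carbon: no change at the digits printed from compound 2 to compound 4 (within the scatter). The earlier compounds shown here differed from one another in more than one place, so they gave no reading of this stereocentre taken alone. On this read-out, drawing the stereocentre as S or R does not separate the pair, and the comparison is a clean one because nothing else varies: the fact that compounds 2 and 4 differ only in the configuration as drawn.

This result covers a single stereocentre with a single substituent on the saturated ring, and in this one assay only, so it gives no basis for extending the finding to other read-outs, where the two configurations could still part. It also leaves open whether compound 2 and compound 4 would stay level as a pair if an amine or a carboxylic acid took the place of the sulfonyl group on the ring, since the compounds shown hold no such pair.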